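Nitro for nitrile on the iodo-bearing ring

The compounds below may be only part of what the source reports. "The series", "measured", "known", "first", "only" and "open" are said of these compounds alone.

Compound 2 `Cc1nc(C#Cc2cc(I)cc(C#N)c2)cs1` was examined in an assay on HEK293 cells for displacement of a labelled ligand from metabotropic glutamate receptor 5 (Rattus norvegicus), read by scintillation counting (on this read-out higher numbers stand for weaker inhibition and lower numbers for stronger inhibition), where compound 2 gives 2.14 nM. Among the two compounds measured here it stands at the higher number; the other, compound 1 `Cc1nc(C#Cc2cc(Br)cc([N+](=O)[O-])c2)cs1`, carries a bromo and a nitro group, and in this assay compound 1 gives 0.93 nM, a gap beyond the usual scatter. Compound 3 `Cc1nc(C#Cc2cc(I)cc([N+](=O)[O-])c2)cs1` has not yet been measured. It differs from compound 2 by nitro in place of cyano on an aromatic carbon. Among the compounds with values here, no direct step between measured compounds covers this exchange, so the expectation rests on compound 1, whose nitro group goes with the lower number. A step toward a lower number, modest in size, is therefore expected: the expected step is a 2.1-fold lower number from compound 2 to compound 3 (0.33 log units; beyond the scatter). On that basis compound 3 is expected to give about 1 nM in this assay, most likely between 0.4 nM and 2.5 nM.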

Compound 3, inhibition constant: 1.84 nM
Estimate against measurement, compound 3: 1.8-fold (0.26 log units) below; low and high end bracket the measured number.
By their numbers in this assay, from the lowest: compounds 1, 3 and 2 (each within the scatter of the next, the first and the last beyond it).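

In this assay, nitro in place of cyano on an aromatic carbon can now be read on its own, and it gives a 1.2-fold lower number from compound 2 to compound 3 (0.07 log units; within the scatter) with the iodo group held fixed, so the two groups are not told apart at this position on the core of compound 3. With the nitro group held fixed, iodo in place of bromo gives a 2.0-fold higher number from compound 1 to compound 3 (0.30 log units; within the scatter) and thus adds a second single exchange that does not separate its pair. Nothing at hand accounts for either step.

The compounds leave open how this position would respond to an amine, a carboxylic acid or a longer chain in place of the nitro or cyano group. They also leave open whether a chloro or methyl group could take the place of the iodo or bromo group.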